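Chloro for hydrogen on the core of compound 1

The source may hold more compounds than are shown below. What is called first, only, known or untested is meant among the compounds shown, and "the series" means these compounds.

Three compounds have numbers in a functional assay on EKVX cells (Homo sapiens) for cytotoxicity, read by sulforhodamine B assay, with a stated time of 48 h; on this read-out lower numbers stand for stronger inhibition of growth and higher numbers for weaker inhibition of growth. Compound 1 `ClCc1ccc(Cn2cnc3c(Cl)ncnc32)cc1` gives 6920 nM, the second highest of the three. Compound 2 `ClCc1cccc(Cn2cnc3c(Cl)nc(Cl)nc32)c1` gives 2310 nM, a lower number beyond the scatter. Compound 3 `Nc1nc(Cl)c2ncn(Cc3ccccc3CCl)c2n1` gives 30900 nM, the highest number, again beyond the scatter from compound 1. Compound 4 `ClCc1ccc(Cn2cnc3c(Cl)nc(Cl)nc32)cc1` is not yet measured; it differs from compound 1 by chloro in place of hydrogen on an aromatic carbon. Within the data shown here, no measured pair isolates this change, so the size of the step is uncertain. A modest move toward stronger growth inhibition is expected, beyond the scatter but not by much, since compound 2 gives 2310 nM. The expected step in this assay is a 2.2-fold lower number from compound 1 to compound 4 (0.33 log units; beyond the scatter). For compound 4 the estimate is 3200 nM, with a range from 1100 nM to 9500 nM.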

Compound 4, concentration for total growth inhibition: 31600 nM
Beside the measured number, compound 4's estimate is 9.9-fold (0.99 log units) below it; measured number above the stated range.
By their numbers in this assay, from the lowest: compound 2; then compound 1; then compounds 3 and 4 (each within the scatter of the next).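

Putting chloro on the aromatic carbon between two ring nitrogen atoms gives a 4.6-fold higher number from compound 1 to compound 4 (0.66 log units; beyond the scatter) in this assay, a move toward weaker growth inhibition. This single matched pair shows that, on the core of compound 1, this position does not accept chloro without a loss. Nothing at hand accounts for that loss.

From the compounds shown here alone, whether the loss is specific to chloro remains open, and fluoro, methyl or methoxy on this carbon would test that. Also open, going by these compounds, is whether the same change costs as much with the chloromethyl group placed differently.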